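Swapping an Amino Group for an Ethyl Group

The compounds below may be only part of what the source reports. "The series", "measured", "known", "first", "only" and "open" are said of these compounds alone.

Compound 1, `CC(C)=CCOc1cc(Nc2ncnc(N)n2)ccc1Cl`, in an ADME assay on MT2 cells (Homo sapiens) for cytotoxicity (on this read-out higher numbers stand for lower toxicity in this test and lower numbers for higher toxicity in this test), gives 48000 nM.
Compound 2, `CC(C)=CCOc1cc(Nc2nccc(N)n2)ccc1Cl`, in this assay gives 500 nM.

Compound 2 stands at the lowest of the two numbers, so it is the more toxic of the pair in this assay. For the measured compounds named here, the one measured step is a 96-fold lower number from compound 1 to compound 2 (1.98 log units; beyond the scatter), and it concerns a change of the ring, not of the groups on it.

The next compound is compound 3, `CCc1ccnc(Nc2ccc(Cl)c(OCC=C(C)C)c2)n1`. It differs from compound 2 in one place: ethyl in place of amino on an aromatic carbon. Going by the values given here, no measured step touches this kind of change, so the data give no guide to its direction or size in this assay, and the estimate must be broad and centred close to compound 2.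

Compound 3 is therefore expected to give about 800 nM, with a range from 150 nM to 8000 nM. The step this estimate implies is a 1.6-fold higher number from compound 2 to compound 3 (0.20 log units; within the scatter), expected to stay within the scatter.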

Compound 3, half-maximal cytotoxic concentration: 330 nM
Beside the measured number, compound 3's estimate is 2.4-fold (0.38 log units) above it, within the range that was stated.
By their numbers in this assay, from the lowest: compounds 3 and 2 (each within the scatter of the next); then compound 1.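

In this assay, ethyl in place of amino on this aromatic carbon gives a 1.5-fold lower number from compound 2 to compound 3 (0.18 log units; within the scatter) and so leaves the two compounds indistinguishable. The amino group, with its hydrogen-bond donor and acceptor, can therefore give way at this place on the ring to an ethyl group, which has neither, with no change beyond the scatter in this pair. None of the measurements available bears on this result.

As far as these compounds go, whether the same holds for other groups at this place, such as a methyl, a propyl chain, a methylamine or a carboxylic acid, remains open. So does whether ethyl would behave the same way on the core of compound 1, where the ring change alone separates that compound from compound 2.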